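The compounds below may be only part of what the source reports. "The series", "measured", "known", "first", "only" and "open" are said of these compounds alone.

Compound 1 `CC(=O)c1ccc(/C=C(/Sc2ccc(C)cc2)C(=O)c2ccc(Br)cc2)cc1` and compound 2 `Cc1ccc(S/C(=C/c2ccc(N(C)C)cc2)C(=O)c2ccc(Br)cc2)cc1` share one core and differ in a single group on an aromatic carbon. In a functional assay on DU-145 cells (Homo sapiens) for inhibition, read by trypan blue exclusion, with a stated time of 96 h (a higher number here means a weaker inhibitor of growth, a lower number a stronger inhibitor of growth), compound 1 gives 50000 nM. Compound 2 gives no number in this assay but only a limit, > 100000 nM. For the measured compounds named here, the one measured step, an at least 2.0-fold higher number from compound 1 to compound 2 (0.30 log units; that floor lies within the scatter), therefore rests on the limit of > 100000 nM in this assay, at which 1 of the 2 values shown sits, and sets only a floor for its size. Compound 3 `Cc1ccc(S/C(=C/c2ccc(Cl)cc2)C(=O)c2ccc(Br)cc2)cc1` is reached from compound 2 by one change: chloro in place of dimethylamino on an aromatic carbon. Going by the values given here, no measured pair shows this change itself; the step from compound 1 to compound 2 bears on it only in that it brought in the group now leaving and moved the number up to the limit. Taking that group out again is therefore expected to bring the number back down, by an at least 2.0-fold lower number from compound 2 to compound 3 (0.30 log units; that floor lies within the scatter). In this assay compound 3 is estimated at 50000 nM, with a range from 15000 nM to 150000 nM.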

Compound 3, concentration for 50% growth inhibition: 10000 nM
Compound 3: the middle estimate sits 5.0-fold (0.70 log units) above what was measured; the measured number lies below the stated range.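

With chloro on an aromatic carbon, para to a large group, the position gives its first step in this assay that is clearly beyond the scatter: an at least 10-fold lower number from compound 2 to compound 3 (1.00 log units; beyond the scatter). Chloro also compares well with acetyl at the same place, with a 5.0-fold lower number from compound 1 to compound 3 (0.70 log units; beyond the scatter), which makes compound 3 the strongest inhibitor of growth of the three compounds. The size of the step from dimethylamino to chloro remains only a floor, as compound 2 has a limit and no number: the limit of > 100000 nM in this assay, at which 1 of the 3 values shown sits.

The compounds shown leave open whether this gain is particular to chloro or would also appear with fluoro, methoxy or a carboxylic acid at this place. From the compounds shown here alone, it also remains open whether the order of these three groups would hold if other parts of the shared core were changed.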